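Changing the amide substituent on a shared core

The source may hold more compounds than are shown below. What is called first, only, known or untested is meant among the compounds shown, and "the series" means these compounds.

Three compounds have been measured:
Compound 1 `Cc1ccccc1NC(=O)CCC(=O)OCCCCCCSc1ccc([N+](=O)[O-])c2nonc12`: 4660 nM
Compound 2 `O=C(CCC(=O)OCCCCCCSc1ccc([N+](=O)[O-])c2nonc12)Nc1ccc(Br)cc1`: 2710 nM
Compound 3 `CN(C)CCNC(=O)CCC(=O)OCCCCCCSc1ccc([N+](=O)[O-])c2nonc12`: 2190 nM

All three share one core and differ only in the group carried on the amide-type nitrogen. In a functional assay on 143B cells (Homo sapiens) for inhibition, read by MTT assay, with a stated time of 72 h (a lower number here means a stronger inhibitor, a higher number a weaker inhibitor), compound 1 gives the highest number of the three, so it is the weakest inhibitor among them. The nearest to it is compound 2, with a 1.7-fold lower number from compound 1 to compound 2 (0.24 log units; within the scatter); the furthest is compound 3, with a 2.1-fold lower number from compound 1 to compound 3 (0.33 log units; beyond the scatter). Between compound 2 and compound 3 the gap is a 1.2-fold lower number from compound 2 to compound 3 (0.09 log units; within the scatter).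

Compound 4 `O=C(CCC(=O)OCCCCCCSc1ccc([N+](=O)[O-])c2nonc12)NCCN1CCCC1` has not yet been measured. It differs from compound 1 in one place: 2-(pyrrolidin-1-yl)ethyl in place of 2-methylphenyl on an amide-type nitrogen. Among the measured compounds shown here, the step that bears most on this change is the one from compound 1 to compound 3, where a 2-(dimethylamino)ethyl group on the same nitrogen also replaced 2-methylphenyl; that step was modest but beyond the scatter. The 2-(pyrrolidin-1-yl)ethyl group of compound 4 likewise carries a basic-type nitrogen on a two-carbon chain, so a step of similar size and direction is expected: a 2.1-fold lower number from compound 1 to compound 4 (0.33 log units; beyond the scatter). For compound 4 the estimated value in this assay is therefore 2200 nM, with a likely range from 1000 nM to 4800 nM.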

Compound 4, half-maximal inhibitory concentration: 5580 nM
Estimate against measurement, compound 4: 2.5-fold (0.40 log units) below; measured number above the stated range.
By their numbers in this assay, from the lowest: compounds 3, 2, 1 and 4 (each within the scatter of the next, the first and the last beyond it).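

In this assay, the change from dimethylamino to pyrrolidin-1-yl on a saturated chain carbon, two bonds along the chain from an amide-type nitrogen, gives a 2.5-fold higher number from compound 3 to compound 4 (0.41 log units; beyond the scatter), so this position responds to the group on the chain and not just to the presence of the chain. The type of group on the amide-type nitrogen does not sort these compounds either: there is a 1.2-fold higher number from compound 1 to compound 4 (0.08 log units; within the scatter), which places a 2-(pyrrolidin-1-yl)ethyl compound level with a 2-methylphenyl compound, while there is a 2.1-fold higher number from compound 2 to compound 4 (0.31 log units; beyond the scatter), which sets it apart from a 4-bromophenyl compound. No measurement shown here accounts for the gap between the pyrrolidin-1-yl and dimethylamino groups.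

As far as these compounds go, it remains open whether other cyclic amines on the same chain, such as piperidin-1-yl or morpholin-4-yl, would read like compound 3 or like compound 4. Also unsettled is how a longer chain between the amide-type nitrogen and the amine, or a carboxylic acid in place of the amine, would read.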